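The compounds below may be only part of what the source reports. "The series", "measured", "known", "first", "only" and "open" are said of these compounds alone.

In a functional assay on HCT-116 cells (Homo sapiens) for inhibition, read by MTT assay, with a stated time of 72 h (on this read-out lower numbers stand for stronger inhibition and higher numbers for weaker inhibition), compound 1 `CC1=NN(c2ccccc2)C(=O)[C@@]12C(=O)C=CC[C@@H]2c1ccc(C)cc1` gives 5220 nM and compound 3 `CC1=NN(c2ccccc2)C(=O)[C@@]12C(=O)C=CC[C@@H]2c1ccccc1` gives 6070 nM. These two share the low end of the three numbers, while compound 2 `COc1ccccc1[C@H]1CC=CC(=O)[C@@]12C(=O)N(c1ccccc1)N=C2C` gives 13900 nM.

Compound 4 `CC1=NN(c2ccc(C)cc2)C(=O)[C@@]12C(=O)C=CC[C@@H]2c1ccc(C)cc1` differs from compound 1 by methyl in place of hydrogen on an aromatic carbon, phenyl to 4-methylphenyl (methyl in place of hydrogen on an aromatic carbon). Among the measured compounds shown here, no measured step makes this change at that place. The closest evidence is the removal of a methyl elsewhere in the molecule, a 1.2-fold higher number from compound 1 to compound 3 (0.07 log units; within the scatter), which stays within the scatter. The two steps involving methoxy, a 2.7-fold higher number from compound 1 to compound 2 (0.43 log units; beyond the scatter) and a 2.3-fold lower number from compound 2 to compound 3 (0.36 log units; beyond the scatter), are modest and concern a different group, so they bear on this change only weakly.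

On this evidence, a methyl added to an aromatic carbon is not expected to move the number beyond the scatter in this assay. The expected step is a 1.0-fold lower number from compound 1 to compound 4 (0.02 log units; within the scatter), which is small. For compound 4 the estimated value is 5000 nM, with an expected range of 2500 nM to 10000 nM.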

Compound 4, half-maximal inhibitory concentration: 4150 nM
Compound 4: the middle estimate sits 1.2-fold (0.08 log units) above what was measured, within the range that was stated.
By their numbers in this assay, from the lowest: compounds 4, 1 and 3 (each within the scatter of the next); then compound 2.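

In this assay the change from phenyl to 4-methylphenyl, methyl in place of hydrogen on an aromatic carbon para to a large group, gives a 1.3-fold lower number from compound 1 to compound 4 (0.10 log units; within the scatter) and so stays within the scatter. Among the compounds shown here, this is the first measured change at this position, which therefore accepts a methyl with no step beyond the scatter. The earlier compounds shown here showed a methyl step only at another place, a 1.2-fold higher number from compound 1 to compound 3 (0.07 log units; within the scatter), and the two methyl steps now agree in staying within the scatter. Nothing measured here gives a reason for the size of this step.

As far as these compounds go, whether an amine or a carboxylic acid at this position would move the number beyond the scatter remains open. So does whether a methyl here would give a similar step on the background of compound 2.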